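A few compounds are considered here, and "the series" means these few. Any claim that something is new, unique, unknown or untested is made for them only; others in the source may bear on it.

Measured compounds:
compound 1, `COc1cc(C(c2ccc(O)c(OC)c2)[C@H](C)[C@@H](C)CF)ccc1O`, 34000 nM
compound 2, `COc1cc(C(c2ccc(O)c(OC)c2)[C@H](CC(C)C)C(C)C)ccc1O`, 8200 nM

Of the two compounds measured in a functional assay on HeLa cells (Homo sapiens) for cytotoxicity, read by WST assay, with a stated time of 48 h (a lower number here means a stronger inhibitor, a higher number a weaker inhibitor), compound 2 has the lower number, and the gap to compound 1 lies beyond the scatter: a 4.1-fold lower number from compound 1 to compound 2 (0.62 log units; beyond the scatter). Compound 3, `COC[C@H](C)[C@H](C)C(c1ccc(O)c(OC)c1)c1ccc(O)c(OC)c1`, has not yet been measured. It differs from compound 2 in one place: 2-(methoxymethyl)-1-methylpropyl in place of 1-isopropyl-3-methylbutyl on a saturated chain carbon bound to two aromatic carbons.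

Going by the values given here, only one measured step bears on this change, the one from compound 1 to compound 2, and it was modest, with the all-carbon chain of compound 2 giving the lower number. Compound 3 moves away from that chain toward a shorter one that carries an oxygen, which makes it closer in kind to compound 1 than to compound 2. The expectation therefore is a step back toward a higher number in this assay, beyond the scatter but probably not much past where compound 1 stands.

Compound 3 is expected to give about 25000 nM in this assay, within a range of 10000 nM to 60000 nM. This estimate implies a step of a 3.0-fold higher number from compound 2 to compound 3 (0.48 log units; beyond the scatter).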

Compound 3, half-maximal inhibitory concentration: 72000 nM
Estimate against measurement, compound 3: 2.9-fold (0.46 log units) below; the measured number lies above the stated range.
By their numbers in this assay, from the lowest: compound 2; then compound 1; then compound 3.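

At this place on the saturated chain carbon bound to two aromatic carbons, the result in this assay shows that the position responds to more than the all-carbon chain against the fluorine-bearing one: 2-(methoxymethyl)-1-methylpropyl in place of 1-isopropyl-3-methylbutyl gives an 8.8-fold higher number from compound 2 to compound 3 (0.94 log units; beyond the scatter) and so places compound 3 at the high end of the three. The two chains that share the 1-methylpropyl frame are not interchangeable either, since methoxymethyl in place of fluoromethyl gives a 2.1-fold higher number from compound 1 to compound 3 (0.33 log units; beyond the scatter) and this step, though small, lies beyond the scatter. Among these three compounds, both chains carrying a fluorine or an oxygen stand above the all-carbon chain of compound 2, and no compound shown goes against that order.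

The compounds shown leave open whether the oxygen itself or the change in chain size and branching accounts for the step to compound 3, as the two differ together here. On these data alone, it also remains open how a chain ending in an amine or a carboxylic acid, or a longer all-carbon chain, would stand in this assay. No measurement at hand explains the differences among these chains.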